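Fluorine on the Phenyl Ring of Compound 3

A few compounds are considered here, and "the series" means these few. Any claim that something is new, unique, unknown or untested is made for them only; others in the source may bear on it.

Of the compounds shown here, three sharing one core have been tested in a functional assay on CHO-K1 cells for antagonist activity at adenosine receptor A1 (Homo sapiens), read by a beta-galactosidase reporter and cAMP accumulation, with stated times of 15 min and 6 h; a higher number here means a weaker inhibitor, a lower number a stronger inhibitor. Compound 1 `Cc1ccc(-c2nc(N)c3cc(Cc4ccccc4)sc3n2)o1` gives 298 nM. Compound 2 `Nc1nc(-c2cnco2)nc2sc(Cc3ccccc3)cc12` gives 106 nM, and compound 3 `Nc1nc(-c2ccccc2)nc2sc(Cc3ccccc3)cc12` gives 151 nM. Among these three numbers compound 3 holds the second highest place; its gaps to compound 2 and to compound 1 both stay within the usual scatter, so no order between them can be claimed.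

Compound 4 `Nc1nc(-c2cccc(F)c2)nc2sc(Cc3ccccc3)cc12` differs from compound 3 in one place: fluoro in place of hydrogen on an aromatic carbon. Going by the values given here, no measured step swaps hydrogen for fluoro. The steps that exist exchange the whole aryl group: a 2.8-fold lower number from compound 1 to compound 2 (0.45 log units; beyond the scatter), a 2.0-fold lower number from compound 1 to compound 3 (0.30 log units; within the scatter) and a 1.4-fold higher number from compound 2 to compound 3 (0.15 log units; within the scatter). Even replacing one ring by another shifted this assay only modestly or within the scatter, so a single fluorine on the phenyl ring is expected to shift it little. The step from compound 3 to compound 4 is therefore estimated as a 1.2-fold lower number from compound 3 to compound 4 (0.07 log units; within the scatter), no change beyond the scatter. Compound 4 is expected to give about 130 nM, within a range from 55 nM to 310 nM.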

Compound 4, inhibition constant: 123 nM
Compound 4: the middle estimate sits 1.1-fold (0.02 log units) above what was measured, within the range that was stated.
By their numbers in this assay, from the lowest: compounds 2, 4, 3 and 1 (each within the scatter of the next, the first and the last beyond it).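

In this assay, going by these compounds alone, putting fluoro in place of hydrogen on the phenyl ring, meta to a large group, gives a first direct reading of this position, and the change stays within the scatter (a 1.2-fold lower number from compound 3 to compound 4 (0.09 log units; within the scatter)). The 3-fluorophenyl group also stays within the scatter of the 1,3-oxazol-5-yl group (a 1.2-fold higher number from compound 2 to compound 4 (0.06 log units; within the scatter)), yet it stands modestly but clearly apart from the 5-methylfuran-2-yl group (a 2.4-fold lower number from compound 1 to compound 4 (0.38 log units; beyond the scatter)), a separation that the unsubstituted phenyl of compound 3 did not reach. No measurement shown here bears on the reason for these results.

Within the data shown here, a single fluorine shows only that this one small change is tolerated at this place on the ring. As far as these compounds go, whether a larger group here, such as a methoxy group, an amine or a carboxylic acid, would shift the number beyond the scatter remains open.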